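The source may hold more compounds than are shown below. What is called first, only, known or untested is meant among the compounds shown, and "the series" means these compounds.

In a functional assay on MIA PaCa-2 cells (Homo sapiens) for cytotoxicity, read by MTT assay, with a stated time of 72 h (a lower number here means a stronger inhibitor, a higher number a weaker inhibitor), compound 2 (`CCc1ccc(-c2ccc(NC3=CC(=O)c4ncncc4C3=O)cc2)cc1`) gives 1500 nM and sits within the usual scatter of compound 1 (`O=C1C(Nc2cccc(-c3ccccc3)c2)=CC(=O)c2ncncc21`) at 2400 nM and so cannot be separated from it. Compound 3 (`CC1=C(Nc2ccc(N3CCN(C)CC3)cc2)C(=O)c2cncnc2C1=O`) gives 3630 nM and this number is higher than that of compound 2 by more than the scatter. The unmeasured compound 4 (`O=C1C(Nc2ccc(-c3ccccn3)cc2)=CC(=O)c2ncncc21`) has pyridin-2-yl in place of the 4-ethylphenyl of compound 2, on an aromatic carbon of a six-membered aromatic ring of carbon only, para to a large group (pyridin-2-yl in place of 4-ethylphenyl on an aromatic carbon). Going by the values given here, no two measured compounds differ in one place, so no measured step shows what this swap does. Among the compounds with values here, the only guide is that compound 1 at 2400 nM and compound 2 at 1500 nM stay within the scatter of each other although their outer groups differ. A step beyond the scatter is therefore not expected, and the estimated step of a 1.7-fold higher number from compound 2 to compound 4 (0.22 log units; within the scatter) leans only slightly toward a higher number. In this assay compound 4 is estimated at about 2500 nM (expected range 900 nM to 7000 nM).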

Compound 4, half-maximal inhibitory concentration: 2000 nM
Beside the measured number, compound 4's estimate is 1.3-fold (0.10 log units) above it; measured number inside the range.
By their numbers in this assay, from the lowest: compounds 2, 4, 1 and 3 (each within the scatter of the next, the first and the last beyond it).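

In this assay, the swap of 4-ethylphenyl for pyridin-2-yl, on an aromatic carbon of a six-membered aromatic ring of carbon only, para to a large group, gives the first single-place comparison among these compounds: a 1.3-fold higher number from compound 2 to compound 4 (0.12 log units; within the scatter). At this position, therefore, a six-membered aromatic ring with 1 hetero atom and 6 heavy atoms can stand in for a carbon-only ring group with 8 heavy atoms, with no difference that can be told from the scatter. No measurement here speaks to why the two compounds cannot be separated.

Going by these compounds, what an amine, a carboxylic acid or a longer alkyl chain would do at this position stays open. On these data alone, compound 1 and compound 3 differ from these compounds in more than one place, so it also stays open whether this swap would behave the same way on another framework.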